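The source may hold more compounds than are shown below. What is called first, only, known or untested is meant among the compounds shown, and "the series" means these compounds.

In a functional assay on KBVIN cells (Homo sapiens) for antiproliferative activity, read by sulforhodamine B assay, with a stated time of 3 days (a higher number here means that more compound is needed for the effect, a lower number that less compound is needed), compound 1 `CCC1=C(O)c2c(oc(-c3ccc(OC)cc3)cc2=O)C(CC)(CC)C1=O` gives 0.68 uM while compound 2 `CCOc1ccc(-c2cc(=O)c3c(o2)C(CC)(CC)C(=O)C(CC)=C3O)cc1` gives 7.54 uM and compound 3 `CCCOc1ccc(-c2cc(=O)c3c(o2)C(CC)(CC)C(=O)C(CC)=C3O)cc1` gives 29.2 uM on the same shared core. Compound 2 thus has the second highest of the three numbers. Only the saturated chain on the aromatic oxygen differs among them, and the number rises as that chain lengthens. There is an 11-fold higher number from compound 1 to compound 2 (1.04 log units; beyond the scatter) which is large, then a 3.9-fold higher number from compound 2 to compound 3 (0.59 log units; beyond the scatter) which is modest, and in sum a 43-fold higher number from compound 1 to compound 3 (1.63 log units; beyond the scatter) across the three. The change to compound 4 `CCC1=C(O)c2c(oc(-c3cccc(C)c3)cc2=O)C(CC)(CC)C1=O` is of another kind, with 3-methylphenyl in place of 4-ethoxyphenyl on an aromatic carbon so that the oxygen and its chain are gone. Among the compounds with values here, no measured step removes that oxygen, so these steps offer only indirect guidance. Still, the shortest chain, in compound 1 at 0.68 uM gave the lowest number, which points downward. A modest move in this assay is expected, and the estimate is a 2.5-fold lower number from compound 2 to compound 4 (0.40 log units; beyond the scatter) with wide uncertainty. For compound 4 the estimated value is 3 uM within an expected range of 0.7 uM to 15 uM in that measurement.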

Compound 4, concentration for half-maximal effect: 3.69 uM
The estimate for compound 4 lay 1.2-fold (0.09 log units) below the measured number; low and high end bracket the measured number.
By their numbers in this assay, from the lowest: compound 1; then compound 4; then compound 2; then compound 3.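

In this assay, putting 3-methylphenyl in place of 4-ethoxyphenyl on the aromatic carbon next to the ring oxygen gives a 2.0-fold lower number from compound 2 to compound 4 (0.31 log units; beyond the scatter) and shows that this position does not need an oxygen-linked chain for activity. The same kind of change made from the shorter chain goes the other way and gives a 5.4-fold higher number from compound 1 to compound 4 (0.73 log units; beyond the scatter) so the direction of the change depends on the group that leaves, and compound 1 keeps the lowest number of the four. No measurement shown here explains this reversal. The change from compound 2 to compound 4 alters both the kind of group and its place on the phenyl ring, so 4-methylphenyl and 3-methoxyphenyl would be needed to separate those two effects. Also open, from the compounds shown here alone, is what an unsubstituted phenyl, or a phenyl carrying an amine or a carboxylic acid, would give.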